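The compounds below may be only part of what the source reports. "The series", "measured", "known", "first", "only" and "open" are said of these compounds alone.

In a functional assay on NALM-6 cells (Homo sapiens) for cytotoxicity, with a stated time of 72 h (on this read-out higher numbers stand for an effect only at larger amounts of compound and lower numbers for an effect already at smaller amounts), compound 1 `C=C[C@@](C)(/C=C/c1ccc(OCc2ccccc2)cc1)CCC=C(C)C` gives only a limit, > 43400 nM. Compound 3 `CC(C)=CCC[C@@](C)(/C=C/c1ccc(C)cc1)/C=C/c1ccc(O)cc1` also gives only a limit, > 43400 nM. Compound 2 `C=C[C@@](C)(/C=C/c1ccc(O)c(CO)c1)CCC=C(C)C` is the one of these three with an actual number, 16400 nM. Compound 1 therefore stands at the limit of > 43400 nM in this assay, at which 2 of the 3 values shown sit.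

Compound 4 `C=C[C@@](C)(/C=C/c1ccc(Nc2ccccc2)cc1)CCC=C(C)C` keeps the core of compound 1 but carries anilino in place of benzyloxy on an aromatic carbon, para to a large group: anilino in place of benzyloxy on an aromatic carbon. For the measured compounds named here, no two measured compounds differ in just one place, so no measured step can serve as a guide for this change. Compound 2, at 16400 nM, does show that a compound of this family can give a number in this assay, so a number for compound 4 is possible. The expected change is small and towards lower numbers, an at least 1.5-fold lower number from compound 1 to compound 4 (0.19 log units; that floor lies within the scatter), and a second limit would be no surprise. Compound 4 is estimated at 28000 nM, with an expected range from 11000 nM to 60000 nM.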

Compound 4, half-maximal effective concentration: > 43400 nM
Compound 4 gave a limit, no number; the forecaster's own chance of this, stated with the estimate: 45%; middle value at least 1.5-fold (0.19 log units) away from the limit.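

Compound 1 and compound 4 both give only a limit, not a number, in this assay and so the step between them cannot be read: the limit of > 43400 nM in this assay, at which 3 of the 4 values shown sit.

As far as these compounds go, whether anilino in place of benzyloxy shifts the effect on these cells in either direction stays open.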